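The source may report more compounds than this note shows. Statements on the series, on what has been measured and on what is new or still open speak of the compounds shown alone.

Compound 1 `CCOC(=O)/C=C/c1ccncc1-c1ccc2ccccc2c1` gives 102% in an assay on a protein complex for inhibition of CDK8/Cyclin C (Homo sapiens), with a stated time of 1 h, tested at 10 uM; a higher number here means more inhibition at the concentration tested (going by the name of the read-out), a lower number less inhibition. For the measured compounds named here, compound 2 `O=C(O)CCNC(=O)/C=C/c1ccncc1-c1ccc2ccccc2c1` gives 91% in this assay, and the only measured step on the carbonyl carbon, a number 11 percentage points lower from compound 1 to compound 2 (beyond the scatter), is the sole comparison available. Compound 2 therefore stands as the lower of the two numbers, with compound 1 higher by a step beyond the scatter.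

Compound 3 `O=C(/C=C/c1ccncc1-c1ccc2ccccc2c1)N1CCOCC1` differs from compound 2 at the same carbonyl carbon: morpholin-4-yl in place of (2-carboxyethyl)amino on a carbonyl carbon. Going by the values given here, the one step that bears on this position, a number 11 percentage points lower from compound 1 to compound 2 (beyond the scatter), was modest; it shows that changing the group on this carbonyl carbon moves the read-out only a little while the numbers of both compounds stay high in this assay. For compound 3 the expected step of a number 3 percentage points lower from compound 2 to compound 3 (within the scatter) in this assay is accordingly small, with no clear direction beyond the scatter. Compound 3 is estimated at 88%, within 70% to 100%.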

Compound 3, a percentage reported as inhibition, at one concentration (the size of the read-out at that concentration, not a potency): 99%
Beside the measured number, compound 3's estimate is 11 percentage points below it; measured number inside the range.
By their numbers in this assay, from the lowest: compounds 2, 3 and 1 (each within the scatter of the next, the first and the last beyond it).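

In this assay, the change to morpholin-4-yl gives a number 8 percentage points higher from compound 2 to compound 3 (within the scatter) and so does not separate the ring from the open (2-carboxyethyl)amino chain, even though the entering group has 0 hydrogen-bond donors and the leaving group has 2. The comparison with the ester gives a number 3 percentage points lower from compound 1 to compound 3 (within the scatter) and does not separate morpholin-4-yl from ethoxy either, so compound 3 cannot be ordered against compound 1 or compound 2, although those two lie beyond the scatter of each other. No measurement here explains these numbers.

All three compounds sit high in a read-out taken at one concentration, so any differences in potency between them remain unresolved. A free carboxylic acid directly on the carbonyl carbon, a piperazine ring or a longer chain ending in an amine could still show how far this position can be changed.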